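This account rests on a few compounds, and the source may have more. Where it says the series, first, only, none or still open, it means among the compounds named here.

Compound 2, with the structure `CC(C)[C@@H]1CC[C@@H](C)C[C@@]12N(C)C(=O)[C@@H]1[C@H]3C(=O)N(c4ccccc4)C(=O)[C@H]3ON12`, is one of three closely related compounds studied in a functional assay, read by spectrophotometry, with a stated time of 2 h, tested at 2 mg/mL; on this read-out higher numbers stand for a stronger effect at the one concentration tested and lower numbers for a weaker effect. In this assay compound 2 gives 48.2%. That is the lowest of the three numbers shown, although the gaps to the other two are within the usual scatter of repeated measurements. Compound 1, with the structure `CC(C)[C@@H]1CC[C@@H](C)C[C@@]12N(C)C(=O)[C@@H]1[C@H]3C(=O)N(C)C(=O)[C@H]3ON12`, gives 49.7% in this assay, and compound 3, with the structure `CC(C)[C@@H]1CC[C@@H](C)C[C@@]12N(C)C(=O)[C@@H]1[C@H]3C(=O)N(c4ccc(Cl)cc4)C(=O)[C@H]3ON12`, gives 56.4%. The measured steps between them are all small: a number 1.5 percentage points lower from compound 1 to compound 2 (within the scatter), a number 6.7 percentage points higher from compound 1 to compound 3 (within the scatter) and a number 8.2 percentage points higher from compound 2 to compound 3 (within the scatter).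

Compound 4, with the structure `Cc1ccc(N2C(=O)[C@H]3[C@H](ON4[C@@H]3C(=O)N(C)[C@@]43C[C@H](C)CC[C@H]3C(C)C)C2=O)c(C)c1`, has not yet been measured in this assay. It differs from compound 2 in one place: 2,4-dimethylphenyl in place of phenyl on an amide-type nitrogen in a ring. For the measured compounds named here, the step most relevant to this change is the one in which compound 2 becomes compound 3, where a substituent was added to the same aromatic ring: a number 8.2 percentage points higher from compound 2 to compound 3 (within the scatter), which stayed within the scatter. The change from methyl to an aryl group on the same nitrogen likewise produced no step beyond the scatter. No change in this series has so far moved the read-out beyond the scatter, so compound 4 is expected to show a number 2.8 percentage points higher from compound 2 to compound 4 (within the scatter), and its value in this assay is estimated at 51%, within a range from 38% to 64%.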

Compound 4, a percentage reported as activity, at one concentration (the size of the read-out at that concentration, not a potency): 57%
Estimate against measurement, compound 4: 6 percentage points below; the measured number falls inside the stated range.
By their numbers in this assay, from the lowest: compounds 2, 1, 3 and 4 (each within the scatter of the next).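

In this assay, 2,4-dimethylphenyl in place of phenyl on this amide-type nitrogen gives a number 8.8 percentage points higher from compound 2 to compound 4 (within the scatter) and extends the small set of aryl groups at this position to one with substituents on the ring at two places. Against the other groups at this nitrogen, the same aryl group gives a number 0.6 percentage points higher from compound 3 to compound 4 (within the scatter) and a number 7.3 percentage points higher from compound 1 to compound 4 (within the scatter) so methyl, phenyl, 4-chlorophenyl and 2,4-dimethylphenyl all lie within the scatter of one another, and this position has still shown no change that clearly moves the read-out. Nothing available here explains these numbers. All four groups on this nitrogen are either methyl or an aromatic ring of carbon only, so the compounds shown leave open how an amine, a carboxylic acid or a longer chain such as butyl would read at this position. The core of compound 1 is also shared by all four compounds, which leaves open whether a change elsewhere on it would move the read-out beyond the scatter.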